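The source may report more compounds than this note shows. Statements on the series, on what has been measured and on what is new or still open speak of the compounds shown alone.

Measured so far in a functional assay on HCT-116 cells (Homo sapiens) for antiproliferative activity, read by MTT assay, with a stated time of 48 h (on this read-out higher numbers stand for weaker inhibition and lower numbers for stronger inhibition), are two compounds:
- Compound 1 `COc1cc(-c2nnc3c(OC(C)C)cc(-c4ccc5[nH]ccc5c4)cn23)cc(OC)c1OC` gives 939 nM
- Compound 2 `COc1cc(-c2nnc3c(OC4CCC4)cc(-c4ccc5[nH]ccc5c4)cn23)cc(OC)c1OC` gives 694 nM

Among the measured compounds shown here, on these numbers, compound 2 stands level with the only other measured compound. For the measured compounds named here, the one measured step is a 1.4-fold lower number from compound 1 to compound 2 (0.13 log units; within the scatter) when cyclobutyl replaces isopropyl on an oxygen on an aromatic ring, so this pair cannot be told apart.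

Compound 3 `COc1cc(-c2nnc3c(OC4CN(C(C)(C)C)C4)cc(-c4ccc5[nH]ccc5c4)cn23)cc(OC)c1OC` changes that same place, with 1-(tert-butyl)azetidin-3-yl in place of cyclobutyl. In full, the change reads 1-(tert-butyl)azetidin-3-yl in place of cyclobutyl on an oxygen on an aromatic ring and goes well beyond the earlier swap, in which both groups held carbon only.

Going by the values given here, the step of a 1.4-fold lower number from compound 1 to compound 2 (0.13 log units; within the scatter) is therefore only a weak guide, and no measured compound carries a nitrogen in this group. With so large a change, a modest move towards a higher number in this assay is expected, meaning somewhat weaker inhibition, though no change beyond the scatter remains possible. The expected step is a 2.0-fold higher number from compound 2 to compound 3 (0.30 log units; within the scatter) as a rough estimate. For compound 3 the estimated value is 1400 nM with an expected range from 350 nM to 5000 nM in this assay.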

Compound 3, half-maximal inhibitory concentration: > 10000 nM
Compound 3 gave a limit, no number (the forecaster's own chance of this, stated with the estimate: 5%); middle value at least 7.1-fold (0.85 log units) from the limit.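

This position is more sensitive than the first two compounds suggested. In this assay, 1-(tert-butyl)azetidin-3-yl in place of cyclobutyl on the oxygen gives an at least 14-fold higher number from compound 2 to compound 3 (1.15 log units; beyond the scatter), and the same group in place of isopropyl gives an at least 10-fold higher number from compound 1 to compound 3 (1.02 log units; beyond the scatter), whereas the swap between the two carbon-only groups stayed within the scatter. The reading for compound 3 is a limit of the assay and not a number, so both steps give only a minimum size and the true loss of inhibition may be larger: the limit of > 10000 nM in this assay, at which 1 of the 3 values shown sits.

The new group differs from cyclobutyl in two ways at once, bringing both a ring nitrogen and a tert-butyl, so these compounds cannot show which of the two goes with the loss. From the compounds shown here alone, whether inhibition returns with a plain azetidin-3-yl or a 1-methylazetidin-3-yl, or stays weak with a carbon-only 3-(tert-butyl)cyclobutyl, remains open.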